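A few compounds are considered here, and "the series" means these few. Any claim that something is new, unique, unknown or untested is made for them only; others in the source may bear on it.

Working notes on the series, read in a functional assay on the whole organism with Rattus norvegicus as the target; a lower number here means that less compound is needed, a higher number that more compound is needed for the effect. Compound 1 `CCOCCOC(=O)C(=O)Nc1nc(-c2cc(Cl)no2)cs1` gives > 30 mg/kg, which is a limit of the assay and not a number. Its position is therefore known only as this limit (the limit of > 30 mg/kg in this assay, at which 1 of the 2 values shown sits). Compound 2 `CCOC(=O)C(=O)Nc1nc(-c2cc(C)no2)cs1` gives a true number in this assay, 0.7 mg/kg. Going by the values given here, compound 1 and compound 2 differ in more than one place, so no measured step guides the size of a single change.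

Compound 3 `CCOCCOC(=O)C(=O)Nc1nc(-c2cc(-c3c(F)cccc3Cl)no2)cs1` keeps the core and the ester of compound 1 and carries 2-chloro-6-fluorophenyl in place of chloro on an aromatic carbon. The effect of this exchange has not been measured in the series. The expectation leans on compound 2 at 0.7 mg/kg, which shows that a low dose is reachable with this kind of structure. A shift towards a lower dose, beyond the scatter, is expected, although a second result at the limit remains possible. The estimated step is an at least 6.0-fold lower number from compound 1 to compound 3 (0.77 log units; beyond the scatter). For compound 3 the expected value is 5 mg/kg, with an estimated range from 0.7 mg/kg to 30 mg/kg.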

Compound 3, dose for half-maximal effect: > 30 mg/kg
Compound 3 ended at the assay's limit (the forecaster's own chance of this, stated with the estimate: 35%); middle value at least 6.0-fold (0.77 log units) from the limit.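

Compound 1 and compound 3 both end at a limit of this assay and not at a number, so no step can be read between them: the limit of > 30 mg/kg in this assay, at which 2 of the 3 values shown sit.

The compounds shown leave open whether 2-chloro-6-fluorophenyl in place of chloro on an aromatic carbon changes the dose needed at all, and how far each compound lies past this limit.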